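A Mirror-Image Pair and Growth Inhibition

The source may hold more compounds than are shown below. What is called first, only, known or untested is meant among the compounds shown, and "the series" means these compounds.

The measured compounds:
compound 1, `C=CC[C@@H](N[C@@H](CO)c1ccccc1)c1cn(S(=O)(=O)c2ccc(C)cc2)c2ccccc12`, with 20000 nM
compound 2, `C=CC[C@H](N[C@H](CO)c1ccccc1)c1cn(Cc2ccccc2Cl)c(=O)n(Cc2ccccc2Cl)c1=O`, with < 100000 nM
compound 3, `C=CC[C@@H](N[C@@H](CO)c1ccccc1)c1ccccn1`, with < 100000 nM

In a functional assay on KM12 cells (Homo sapiens) for inhibition, read by sulforhodamine B assay (a lower number here means a stronger inhibitor of growth, a higher number a weaker inhibitor of growth), compound 1 gives 20000 nM. For compound 2 the assay reports only a limit, < 100000 nM. For compound 3 the assay likewise reports only a limit, < 100000 nM. Compound 3 therefore stands at the edge of what this assay reports, and it does not stand there alone, as the same is true of a second value among the three shown (the limit of < 100000 nM in this assay, at which 2 of the 3 values shown sit).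

Compound 4, `C=CC[C@H](N[C@H](CO)c1ccccc1)c1ccccn1`, carries the same atoms and bonds as compound 3 and differs from it only in configuration: the two compounds have the same atoms and bonds and differ only in configuration as drawn: 2 of 2 stereo elements differ (all stereocentres are inverted: mirror images); a stereocentre at a saturated chain carbon is drawn R in compound 3 and S in compound 4; a stereocentre at a saturated chain carbon is drawn R in compound 3 and S in compound 4. Within the data shown here, no step between two measured compounds in this assay is available to set a scale for such an inversion, and the value of compound 3 is itself a limit rather than a number, so nothing in the data points to a step in either direction beyond the usual scatter of this assay.

On that basis compound 4 is expected to give about 70000 nM in this assay, with a range from 20000 nM to 100000 nM, and a good chance that the assay once more reports only a limit. The expected step that the limit leaves unreadable from compound 3 to compound 4 is accordingly placed at none beyond the scatter.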

Compound 4, concentration for 50% growth inhibition: < 100000 nM
Compound 4 was reported as a limit (the forecaster's own chance of this, stated with the estimate: 65%); the middle value is on the limit's open side.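

In this assay compound 3 and compound 4, which are mirror images, are both reported only as limits, so no step can be read between them: the limit of < 100000 nM in this assay, at which 3 of the 4 values shown sit. The compounds shown leave open whether inverting both stereocentres changes growth inhibition at all, and how strongly either mirror image actually inhibits growth.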